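Propyl to butyl in a cytotoxicity series

The compounds below may be only part of what the source reports. "The series", "measured", "known", "first", "only" and "open" are said of these compounds alone.

Measured compounds:
compound 1 `CCCc1ccsc1CN[C@@H]1C[C@H]2C[C@@H]([C@H]1C)C2(C)C`: 50000 nM
compound 2 `C=C(C)c1csc(CN[C@@H]2C[C@H]3C[C@@H]([C@H]2C)C3(C)C)c1`: 25000 nM
compound 3 `CCCc1csc(CN[C@@H]2C[C@H]3C[C@@H]([C@H]2C)C3(C)C)c1`: 12500 nM

In an ADME assay on MDCK cells (Canis lupus familiaris) for cytotoxicity, read by microscopy, with a stated time of 48 h (on this read-out lower numbers stand for higher toxicity in this test and higher numbers for lower toxicity in this test), compound 1 gives the highest of the three numbers; compound 2 is within the scatter of it, while compound 3 sits beyond the scatter, at the lower end. Compound 4 `CCCCc1ccsc1CN[C@@H]1C[C@H]2C[C@@H]([C@H]1C)C2(C)C` differs from compound 1 by methyl in place of hydrogen on a saturated chain carbon, three bonds along the chain from an aromatic carbon. Among the measured compounds shown here, no measured step lengthens a chain by one carbon. For the measured compounds named here, the only step on a chain, a 2.0-fold lower number from compound 2 to compound 3 (0.30 log units; within the scatter), swaps one group for another and stays within the scatter. On this basis no step beyond the scatter is expected for compound 4, so no change at the digits printed from compound 1 to compound 4 (within the scatter) is the expected change. The estimate for compound 4 in this assay is 50000 nM, with a range from 25000 nM to 100000 nM.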

Compound 4, minimum cytotoxic concentration: 25000 nM
For compound 4 the middle estimate is 2.0-fold (0.30 log units) above the measured one; low and high end bracket the measured number.
By their numbers in this assay, from the lowest: compounds 3, 2, 4 and 1 (each within the scatter of the next, the first and the last beyond it).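

In this assay, among the compounds shown here, propyl to butyl gives a 2.0-fold lower number from compound 1 to compound 4 (0.30 log units; within the scatter), the first measured step that lengthens a chain by one carbon. At this position, one added chain carbon therefore stays within the scatter, and compound 4 is not separated from compound 1. Nothing available explains this step.

Going by these compounds, whether a longer chain such as pentyl, or a chain ending in an amine or a carboxylic acid, would also stay within the scatter of compound 1 remains open. So does whether propyl to butyl on compound 3 would give a step of similar size.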